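This account rests on a few compounds, and the source may have more. Where it says the series, first, only, none or still open, it means among the compounds named here.

Working notes on the series.

Compound 1 `C=Cc1c(CC)nn(CCCN2CCN(c3ccc(C)cc3)CC2)c(=O)c1N` gives 0% in a functional assay on the whole organism (Abdomen, strain Swiss) for inhibition, with Mus musculus as the target, with stated times of 30 min, 10 min and 5 min, at a dose of 20 mg/kg by the oral route; a higher number here means a stronger effect of the compound at the dose given, a lower number a weaker effect. Compound 2 `C=Cc1c(CCC)nn(CCCN2CCN(c3ccc(C)cc3)CC2)c(=O)c1N` carries methyl in place of hydrogen on a saturated chain carbon, two bonds along the chain from an aromatic carbon and gives 7% in this assay, a step of a number 7 percentage points higher from compound 1 to compound 2 (within the scatter). Compound 3 `C/C=C/c1c(C)nn(CCCN2CCN(c3ccc(C)cc3)CC2)c(=O)c1N` gives 44% in this assay; how its core differs from that of compound 1 is not broken down here.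

Compound 4 `CC/C=C/c1c(C)nn(CCCN2CCN(c3ccc(C)cc3)CC2)c(=O)c1N` is not yet measured. Within the data shown here, it carries methyl in place of hydrogen on a saturated chain carbon bound to a double-bonded chain carbon, the same kind of change as the one from compound 1 to compound 2, though the place differs: here the carbon is bound to a double-bonded chain carbon, there it lay two bonds along the chain from an aromatic carbon. Among the measured compounds shown here, for compound 4 in this assay a step of a number 2 percentage points higher from compound 3 to compound 4 (within the scatter) is expected, resting on the one earlier step of a number 7 percentage points higher from compound 1 to compound 2 (within the scatter), which stayed within the scatter. Compound 4 is estimated at 46%, between 22% and 66%.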

Compound 4, a percentage reported as inhibition, in the whole organism at one dose (the size of the read-out at that dose, not a potency): 35%
Beside the measured number, compound 4's estimate is 11 percentage points above it; low and high end bracket the measured number.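

Methyl in place of hydrogen on a saturated chain carbon does not carry over from one core to the other as a single fixed step in this assay: the same change on two cores in this assay, a number 7 percentage points higher (within the scatter) from compound 1 to compound 2 and a number 9 percentage points lower (within the scatter) from compound 3 to compound 4, 16 percentage points apart, beyond the scatter of two such steps. The new step, a number 9 percentage points lower from compound 3 to compound 4 (within the scatter), shows no clear effect of the change on the core of compound 3 when read alone; only the gap between the two steps is beyond the scatter. Among these compounds, with only two pairs, and with the changed carbon in a different place in each, the data do not show whether the core or the place accounts for that gap.

Still open, going by these compounds, is how a chain longer than but-1-en-1-yl would read in this assay. Also open, on these data alone, is the effect of an amine or a carboxylic acid on that chain.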